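Chain-Extended Homoserine Lactone Amides and Cytotoxicity

The source may hold more compounds than are shown below. What is called first, only, known or untested is meant among the compounds shown, and "the series" means these compounds.

Measured compounds:
compound 1, `O=C(CCCCCCc1ccccc1)CC(=O)N[C@H]1CCOC1=O`: 65000 nM
compound 2, `O=C(CCCCCCCc1ccccc1)CC(=O)N[C@H]1CCOC1=O`: 42000 nM
compound 3, `O=C(CCCCCCCCc1ccccc1)N[C@H]1CCOC1=O`: > 100000 nM

Of the compounds shown here, three have been tested in a functional assay on NCI-H630 cells (Homo sapiens) for cytotoxicity, read by sulforhodamine B assay, with a stated time of 5 days; a higher number here means a weaker inhibitor, a lower number a stronger inhibitor. Compound 1 `O=C(CCCCCCc1ccccc1)CC(=O)N[C@H]1CCOC1=O` gives 65000 nM. Compound 2 `O=C(CCCCCCCc1ccccc1)CC(=O)N[C@H]1CCOC1=O` carries the change benzyl in place of phenyl on a saturated chain carbon, six bonds along the chain from a carbonyl carbon and gives 42000 nM. The step between them is a 1.5-fold lower number from compound 1 to compound 2 (0.19 log units; within the scatter), so the two values cannot be told apart.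

Compound 3 `O=C(CCCCCCCCc1ccccc1)N[C@H]1CCOC1=O` gives only a limit in this assay, namely > 100000 nM. For compound 3 the relevant fact is the limit of > 100000 nM in this assay, at which 1 of the 3 values shown sits. How the core of compound 3 differs from the core of compound 1 is not broken down here.

Compound 4 `O=C(CCCCCCCCCc1ccccc1)N[C@H]1CCOC1=O` is not yet measured. It is made from compound 3 by benzyl in place of phenyl on a saturated chain carbon, eight bonds along the chain from a carbonyl carbon. Among the compounds with values here, this is the same kind of change as the one from compound 1 to compound 2, though the place differs: there the change sat six bonds along the chain from a carbonyl carbon, here it sits eight bonds along the chain from a carbonyl carbon.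

Because the earlier step of a 1.5-fold lower number from compound 1 to compound 2 (0.19 log units; within the scatter) stayed within the scatter, the step from compound 3 to compound 4 is expected to be small as well, about a number no higher from compound 3 to compound 4 (the limit leaves the size open). Compound 4 is therefore estimated to give around 100000 nM in this assay, with a range expected from 40000 nM to 250000 nM, and a fair chance that only a limit is reported again.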

Compound 4, half-maximal inhibitory concentration: > 100000 nM
Compound 4: only a limit was reported (the forecaster's own chance of this, stated with the estimate: 60%); the middle value sits exactly at the limit.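

In this assay compound 4 gives > 100000 nM, which is a limit and not a number. Compound 3 also gives only a limit, so no step can be read between compound 3 and compound 4. The compounds shown leave open whether benzyl in place of phenyl, on a saturated chain carbon, eight bonds along the chain from a carbonyl carbon, changes the number in this assay at all.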